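The source may hold more compounds than are shown below. What is called first, only, known or untested is meant among the compounds shown, and "the series" means these compounds.

Compound 1, `COc1ccc(/C=C/S(=O)(=O)Cc2ccc(OC)c([N+](=O)[O-])c2)cc1`: 25000 nM
Compound 2, `COc1ccc(/C=C/S(=O)(=O)Cc2ccc(OC)c(N)c2)cc1`: 2500 nM
Compound 3, `COc1ccc(CS(=O)(=O)/C=C/c2c(OC)cccc2OC)cc1[N+](=O)[O-]`: 20000 nM

All three values come from a functional assay on K562 cells (Homo sapiens) for cytotoxicity, read by trypan blue exclusion, with a stated time of 96 h; on this read-out higher numbers stand for weaker inhibition and lower numbers for stronger inhibition. Compound 1 and compound 2 differ in a single place: amino in place of nitro on an aromatic carbon. That one change produced a 10-fold lower number from compound 1 to compound 2 (1.00 log units; beyond the scatter). Compound 3 is built on a different core than compound 1, and the difference between the two cores is not broken down here; the values of compound 3 and compound 1 lie within the scatter of each other. Compound 4, `COc1ccc(CS(=O)(=O)/C=C/c2c(OC)cccc2OC)cc1N`, has not yet been measured. It arises from compound 3 by the same change as before, (amino in place of nitro on an aromatic carbon), at a place described in the same words. Compound 4 is expected to show an 8.0-fold lower number from compound 3 to compound 4 (0.90 log units; beyond the scatter), an expectation that rests on the earlier step of a 10-fold lower number from compound 1 to compound 2 (1.00 log units; beyond the scatter). Compound 4 is therefore estimated at 2500 nM, likely between 900 nM and 7000 nM. Among the measured compounds shown here, only one prior example supports this, so the carry-over is an assumption.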

Compound 4, half-maximal inhibitory concentration: 50 nM
The estimate for compound 4 lay 50-fold (1.70 log units) above the measured number; the whole stated range lies above it.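

In this assay, the change gave a 400-fold lower number from compound 3 to compound 4 (2.60 log units; beyond the scatter), so the number fell on the second core as well. The direction carried over from one core to the other, but the size did not: the same change on two cores in this assay, a 10-fold lower number (1.00 log units; beyond the scatter) from compound 1 to compound 2 and a 400-fold lower number (2.60 log units; beyond the scatter) from compound 3 to compound 4, 40-fold (1.60 log units) apart, beyond the scatter of two such steps

These two pairs do not explain why the size depends on the core, and they give no way to predict the size on a third core. The compounds shown leave open whether a hydroxyl group or an acetamide on that aromatic carbon would behave like amino. It also remains open which difference between the two cores sets the size of the step, as no compound shown separates those differences.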